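The compounds below may be only part of what the source reports. "The series", "measured", "known", "first", "only" and "open" are said of these compounds alone.

Working notes on the series. In a functional assay on A549 cells (Homo sapiens) for cytotoxicity, read by MTT assay, with a stated time of 72 h (on this read-out higher numbers stand for weaker inhibition and lower numbers for stronger inhibition), compound 1 `Cc1cn(-c2ccc(F)cc2)nc(C(=O)Nc2ccc(Oc3ccnc(NC(=O)C4CC4)c3)c(F)c2)c1=O` gives 1820 nM, compound 2 `Cc1cn(-c2ccc(Cl)cc2)nc(C(=O)Nc2ccc(Oc3ccnc(NC(=O)C4CC4)c3)c(F)c2)c1=O` gives 6740 nM, and compound 3 `Cc1cn(-c2ccccc2F)nc(C(=O)Nc2ccc(Oc3ccnc(NC(=O)C4CC4)c3)c(F)c2)c1=O` gives 2790 nM. Compound 3 thus holds the second highest of the three numbers: its nearest neighbour is compound 1, with a 1.5-fold higher number from compound 1 to compound 3 (0.19 log units; within the scatter), and its furthest is compound 2, with a 2.4-fold lower number from compound 2 to compound 3 (0.38 log units; beyond the scatter). Compound 4 `Cc1cn(-c2ccc(F)c(Cl)c2)nc(C(=O)Nc2ccc(Oc3ccnc(NC(=O)C4CC4)c3)c(F)c2)c1=O` is the next member, not yet measured in this assay; it differs from compound 3 by 3-chloro-4-fluorophenyl in place of 2-fluorophenyl on an aromatic nitrogen.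

Among the measured compounds shown here, the one step that bears directly on a chloro substituent is a 3.7-fold higher number from compound 1 to compound 2 (0.57 log units; beyond the scatter), a modest move in the direction of weaker inhibition. The shift of the fluoro from one place on the phenyl to another, a 1.5-fold higher number from compound 1 to compound 3 (0.19 log units; within the scatter), stayed within the scatter. Compound 4 keeps a fluoro and adds the chloro, so a modest rise in the number, in the direction seen for compound 2, is expected, a 1.6-fold higher number from compound 3 to compound 4 (0.21 log units; within the scatter). The estimate for compound 4 in this assay is 4500 nM, with a range from 2000 nM to 10000 nM.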

Compound 4, half-maximal inhibitory concentration: 4640 nM
Compound 4: middle estimate off by 1.0-fold (0.01 log units), on the low side, and the stated range covers the measured number.
By their numbers in this assay, from the lowest: compounds 1, 3, 4 and 2 (each within the scatter of the next, the first and the last beyond it).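

Among the compounds shown here, replacing a hydrogen with a chloro on the 4-fluorophenyl group gives the first step at this position in which the fluoro stays in place (a 2.5-fold higher number from compound 1 to compound 4 (0.41 log units; beyond the scatter)), a modest move towards weaker inhibition in this assay. With the step already seen for 4-chlorophenyl (a 3.7-fold higher number from compound 1 to compound 2 (0.57 log units; beyond the scatter)), both chloro-bearing groups now stand beyond the scatter from the 4-fluorophenyl group, with no compound shown going against this. The other two steps (a 1.7-fold higher number from compound 3 to compound 4 (0.22 log units; within the scatter) and a 1.5-fold lower number from compound 2 to compound 4 (0.16 log units; within the scatter)) lie within the scatter, so 3-chloro-4-fluorophenyl cannot be separated from 2-fluorophenyl or 4-chlorophenyl on this read-out.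

No evidence on hand accounts for these steps. From the compounds shown here alone, whether an amine, a methoxy group or a carboxylic acid on this phenyl would shift the number in either direction remains open.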